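The source may hold more compounds than are shown below. What is called first, only, known or untested is meant among the compounds shown, and "the series" means these compounds.

Working notes on the series. In a toxicity assay on NIH3T3 cells (Mus musculus) for cytotoxicity, read by resazurin assay (on this read-out higher numbers stand for an effect only at larger amounts of compound and lower numbers for an effect already at smaller amounts), compound 1 `COC(=O)c1ccc(NCc2cncn2Cc2ccccc2Cl)cc1-c1ccccc1` gives 10000 nM. Compound 2 `c1ccc(-c2ccc(Cn3cncc3CNc3ccc(-c4nc5ccccc5s4)c(-c4ccccc4)c3)cc2)cc1` is reported only as a limit, > 1000 nM. Compound 3 `Cc1ccccc1-c1cc(NCc2cncn2Cc2ccc(-c3ccccc3)cc2)ccc1-c1nc2ccccc2s1` is also reported only as a limit, > 1000 nM, so its position is bounded on one side and it has no exact value. The series shows (the limit of > 1000 nM in this assay, at which 2 of the 3 values shown sit).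

Compound 4 `Cc1cccc(-c2cc(NCc3cncn3Cc3ccc(-c4ccccc4)cc3)ccc2-c2nc3ccccc3s2)c1C` differs from compound 3 by methyl in place of hydrogen on an aromatic carbon, taking 2-methylphenyl to 2,3-dimethylphenyl. Going by the values given here, the one measured step of the same kind is a step that the two limits leave unreadable from compound 2 to compound 3, so it offers no size to carry over. Among the compounds with values here, no step beyond the scatter and no direction is expected in this assay, since the only comparable change is a step that the two limits leave unreadable from compound 2 to compound 3. The expected change is a step that the limit leaves unreadable from compound 3 to compound 4, and it is an estimate resting on a limit. A further report as a limit is the likeliest outcome. For compound 4 the estimated value is 3000 nM, with an expected range from 1000 nM to 10000 nM.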

Compound 4, half-maximal effective concentration: > 1000 nM
Compound 4: no number, only a limit (the forecaster's own chance of this, stated with the estimate: 75%); the middle value is on the limit's open side.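

Going by these compounds alone, compound 4 is reported only as a limit, > 1000 nM, so no step among compound 2, compound 3 and compound 4 can be read: the limit of > 1000 nM in this assay, at which 3 of the 4 values shown sit. Where these three compounds lie in this assay, and whether either methyl changes the value, stays open.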